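The compounds below may be only part of what the source reports. "The series", "measured", "known", "first", "only" and "open" are said of these compounds alone.

Measured compounds:
Compound 1, `Cc1ccccc1C(CCC(=O)O)Oc1cc(OCc2ccsc2)ccc1-c1ncc[nH]1`: 163000 nM
Compound 2, `Cc1ccccc1[C@@H](CCC(=O)O)Oc1cc(OCc2cccnc2)ccc1C#N`: 5 nM

Both compounds were tested in an assay on A10 cells for binding affinity to Endothelin-1 receptor (Rattus norvegicus); on this read-out higher numbers stand for weaker inhibition and lower numbers for stronger inhibition. Compound 2 gives the lower of the two numbers, 5 nM, whereas compound 1 gives 163000 nM; the two structures differ in several places at once, so this gap cannot be traced to any single change. The unmeasured compound 3, `Cc1ccccc1[C@@H](CCC(=O)O)Oc1cc(OCc2cnsc2)ccc1C#N`, differs from compound 2 in one place only: 1,2-thiazol-4-yl in place of pyridin-3-yl on a saturated chain carbon bound to an oxygen on an aromatic ring. Going by the values given here, no pair of measured compounds isolates this exchange, so there is no measured step to lean on. As the change merely exchanges one aromatic ring for another on the same saturated chain carbon, the step expected from compound 2 to compound 3 in this assay is a 2.0-fold higher number from compound 2 to compound 3 (0.30 log units; within the scatter), a modest weakening that may well stay within the scatter. Compound 3 is therefore estimated at 10 nM, with a likely range from 3 nM to 40 nM.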

Compound 3, half-maximal inhibitory concentration: 7 nM
Beside the measured number, compound 3's estimate is 1.4-fold (0.15 log units) above it; low and high end bracket the measured number.
By their numbers in this assay, from the lowest: compounds 2 and 3 (each within the scatter of the next); then compound 1.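

In this assay, going by these compounds alone, putting 1,2-thiazol-4-yl in place of pyridin-3-yl gives a 1.4-fold higher number from compound 2 to compound 3 (0.15 log units; within the scatter), the first step that isolates a single place. On a saturated chain carbon bound to an oxygen on an aromatic ring, a five-membered aromatic ring with 2 hetero atoms can therefore replace a six-membered aromatic ring with 1 hetero atom with no difference beyond the scatter, something the earlier pair, differing in several places, could not show. No measurement is at hand that explains this match.

From the compounds shown here alone, it remains open whether the same place also accepts a non-aromatic group such as cyclohexyl, or an amine such as piperidin-4-yl. Which of the several differences between compound 1 and compound 2 accounts for their wide gap also remains open.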